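The compounds below may be only part of what the source reports. "The series", "measured", "known", "first", "only" and "open" are said of these compounds alone.

Compound 1, `CC1(C)N=C(N)N=C(N)N1c1ccc(OCCCC(=O)Nc2cccc(S(=O)(=O)F)c2)c(Cl)c1`, was tested in an assay on isolated protein for inhibition of Dihydrofolate reductase (Mus musculus) (a higher number here means a more potent compound, by a factor of ten per unit of this negative logarithm, a lower number a less potent compound), and gives 7.17, the lower of the two values recorded. Compound 2, `CC1(C)N=C(N)N=C(N)N1c1cccc(OCCCCOc2ccc(S(=O)(=O)F)cc2)c1`, gives 7.49 in the same assay, a result lying beyond the usual scatter above compound 1. Compound 3, `CC1(C)N=C(N)N=C(N)N1c1ccc(OCCCC(=O)Nc2ccc(S(=O)(=O)F)cc2)c(Cl)c1`, is the next compound to be measured. It differs from compound 1 in one place: 4-(fluorosulfonyl)phenyl in place of 3-(fluorosulfonyl)phenyl on an amide-type nitrogen. Nothing measured yet shows what this kind of change does here. For compound 3 a modest upward step is expected, a number 0.23 log units higher from compound 1 to compound 3 (within the scatter), which may not exceed the scatter. The estimate for compound 3 is 7.4, between 6.9 and 7.9.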

Compound 3, logarithm of the reciprocal of the active concentration, log(1/C): 7.15
Estimate against measurement, compound 3: 0.25 log units above; the range from low to high includes it.
By their numbers in this assay, from the lowest: compounds 3 and 1 (each within the scatter of the next); then compound 2.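

In this assay, 4-(fluorosulfonyl)phenyl in place of 3-(fluorosulfonyl)phenyl on the amide-type nitrogen gives a number 0.02 log units lower from compound 1 to compound 3 (within the scatter) and so the two compounds cannot be told apart. At this position, then, the two placements of the fluorosulfonyl group on the phenyl ring give matching numbers. Nothing available accounts for this result.

Still open, on these data alone, is whether a different group on that phenyl ring, such as a carboxylic acid or an amine, would shift the number beyond the scatter. As far as these compounds go, a longer chain between the amide and the core of compound 1 is equally open.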